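Benzyl Variation in a Piperidine Sulfonamide Series of M5 Modulators

A few compounds are considered here, and "the series" means these few. Any claim that something is new, unique, unknown or untested is made for them only; others in the source may bear on it.

Measured compounds:
compound 1, `CCN(Cc1ccccc1)C(=O)C1CCN(S(=O)(=O)c2ccc3nsnc3c2)CC1`, 81%
compound 2, `CCN(Cc1ccc(F)cc1)C(=O)C1CCN(S(=O)(=O)c2ccc3cn[nH]c3c2)CC1`, 55%
compound 3, `CCN(Cc1cccc(Cl)c1)C(=O)C1CCN(S(=O)(=O)c2ccc3cn[nH]c3c2)CC1`, 77%

In a functional assay on CHO cells for positive allosteric modulation of muscarinic acetylcholine receptor M5 (Homo sapiens), read by calcium flux (a higher number here means a larger maximal response, a lower number a smaller maximal response), compound 3 gives 77%. Among the three measured compounds it stands second highest; its nearest neighbour is compound 1, whose value lies within the scatter of it, and the furthest is compound 2, whose value is lower by a margin beyond the scatter.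

Compound 4, `CCN(Cc1ccccc1C(F)(F)F)C(=O)C1CCN(S(=O)(=O)c2ccc3cn[nH]c3c2)CC1`, has not yet been measured. It differs from compound 3 in one place: 2-(trifluoromethyl)phenyl in place of 3-chlorophenyl on a saturated chain carbon bound to an amide-type nitrogen.

For the measured compounds named here, only one measured step touches the same place, and it is the step of a number 22 percentage points higher from compound 2 to compound 3 (beyond the scatter). That step concerns a different exchange of substituents on the benzyl group, so it shows that changes here can move the response by a modest amount, but it does not show in which direction the present change will go. Nothing measured bears directly on a 2-(trifluoromethyl)phenyl group.

On that basis compound 4 is expected to give 70% in this assay, within a range of 50% to 90%. The estimated step is a number 7 percentage points lower from compound 3 to compound 4 (within the scatter), a change that need not exceed the scatter.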

Compound 4, largest response reached (reported as percent of maximum), in percent of the reference or control that the assay uses: 92%
Compound 4: the middle estimate sits 22 percentage points below what was measured, and the stated range ends below it.
By their numbers in this assay, from the lowest: compound 2; then compounds 3 and 1 (each within the scatter of the next); then compound 4.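

Read in this assay, the exchange of 3-chlorophenyl for 2-(trifluoromethyl)phenyl gives a number 15 percentage points higher from compound 3 to compound 4 (beyond the scatter) and so shows that this place on the benzyl group has room for a larger maximal response even after the gain seen with the 3-chlorophenyl group. Set against the 4-fluorophenyl group, the same 2-(trifluoromethyl)phenyl group gives a number 37 percentage points higher from compound 2 to compound 4 (beyond the scatter) and so widens the span of responses reached by changing the benzyl group alone while the rest of the molecule stays fixed. No evidence is at hand to explain this rise, and the result cannot separate the contribution of the trifluoromethyl group from that of its place on the ring.

The compounds shown leave open whether the 2-(trifluoromethyl)benzyl group would raise the response on the core of compound 1 as it does on the core of compound 3. They also leave open how a nitrile or a methoxy group on the benzyl ring, or a longer chain in place of the ethyl group on the amide-type nitrogen, would compare with compound 4.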